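The compounds below may be only part of what the source reports. "The series", "measured", "known", "first", "only" and "open" are said of these compounds alone.

The three measured compounds share one core. Compound 1 `Cc1cn(Cc2ccc(Cl)cc2Cl)c2c(-c3cc(NS(=O)(=O)c4cc(Cl)c(Cl)s4)no3)cc(F)cc12` gives, in an assay on isolated protein for displacement of a labelled ligand from prostaglandin E2 receptor EP3 subtype (Homo sapiens) (on this read-out lower numbers stand for stronger inhibition and higher numbers for weaker inhibition), a value of 5 nM. Compound 2 `Cc1cn(Cc2ccc(Cl)cc2Cl)c2c(-c3nnc(NS(=O)(=O)c4cc(F)c(F)cc4F)o3)cc(F)cc12` differs from it in the ring that joins the core to the sulfonamide and in the group on the sulfonyl sulfur; in this assay compound 2 gives 2 nM. Compound 3 `Cc1cn(Cc2ccc(Cl)cc2Cl)c2c(-c3nnc(NS(=O)(=O)c4ccc(Cl)c(Cl)c4)o3)cc(F)cc12` is the nearest relative of compound 2, and in this assay compound 3 gives 4 nM. Among the measured compounds shown here, the only single-place step among them, a 2.0-fold higher number from compound 2 to compound 3 (0.30 log units; within the scatter), stays inside the usual scatter. Compound 3 therefore stands second highest of the three numbers, with compound 1 nearest and compound 2 furthest, both within the scatter of it.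

Compound 4 `Cc1cn(Cc2ccc(Cl)cc2Cl)c2c(-c3nnc(NS(C)(=O)=O)o3)cc(F)cc12` has not yet been measured. The change from compound 3 is methyl in place of 3,4-dichlorophenyl on a sulfonyl sulfur. For the measured compounds named here, no measured step touches this kind of exchange: the step from compound 2 to compound 3 only swaps one six-membered aromatic ring for another and moves nothing beyond the scatter, so it offers no direct guide. Since the change removes the whole ring and leaves a methyl, a step beyond the scatter toward a higher number is expected, about a 38-fold higher number from compound 3 to compound 4 (1.57 log units; beyond the scatter). For compound 4 the estimate in this assay is 150 nM, with a likely range from 20 nM to 1500 nM.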

Compound 4, half-maximal inhibitory concentration: 2570 nM
Beside the measured number, compound 4's estimate is 17-fold (1.23 log units) below it; the measured number lies above the stated range.
By their numbers in this assay, from the lowest: compounds 2, 3 and 1 (each within the scatter of the next, the first and the last beyond it); then compound 4.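

On the sulfonyl sulfur, where exchanging one aromatic ring for another had moved nothing beyond the scatter, this assay now shows a large response: methyl in place of 3,4-dichlorophenyl gives a 640-fold higher number from compound 3 to compound 4 (2.81 log units; beyond the scatter) and methyl in place of 2,4,5-trifluorophenyl gives a 1300-fold higher number from compound 2 to compound 4 (3.11 log units; beyond the scatter) on the same shared core. Among these compounds, then, the group on the sulfonyl sulfur is far from indifferent: the two halogenated aromatic rings of compound 2 and compound 3 stay within the scatter of each other, while the small methyl of compound 4 lies far beyond the scatter from both. Nothing supplied with these numbers accounts for the size of these steps.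

What the compounds shown leave open is how the number changes between methyl and the aromatic rings, and whether a longer chain such as n-butyl, a benzyl group or a cyclohexyl ring on the sulfonyl sulfur would stay close to compound 3 or close to compound 4. Among the compounds shown here, it also remains open whether the same exchange to methyl would have a step of similar size with the joining ring of compound 1 in place of the one carried by compound 3.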